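Adding a second nitrooxy chain to compound 2

The source may hold more compounds than are shown below. What is called first, only, known or untested is meant among the compounds shown, and "the series" means these compounds.

Going by the values given here, in a functional assay on M4E cells (Homo sapiens) for cytotoxicity, read by resazurin assay, with a stated time of 72 h (on this read-out higher numbers stand for weaker inhibition and lower numbers for stronger inhibition), compound 2 `COc1cc(/C=C/C(=O)OCCCCCO[N+](=O)[O-])ccc1O` gives 21800 nM, the only true number so far. In this assay, compound 1 `O=C(/C=C/c1ccc(OCCCCCO[N+](=O)[O-])c(O)c1)OCCCCCO[N+](=O)[O-]` gives > 50000 nM, which is a limit of the assay and not a number. Compound 3 `COc1cc(/C=C/C(=O)OCCCCCO[N+](=O)[O-])ccc1OCCCCCO[N+](=O)[O-]` differs from compound 2 in one place: 5-(nitrooxy)pentyl in place of hydrogen on an oxygen on an aromatic ring, with 5-(nitrooxy)pentyl in place of hydrogen on an oxygen on an aromatic ring. Among the compounds with values here, no measured step shows this change directly. Compound 1 also carries 5-(nitrooxy)pentyl on an oxygen on an aromatic ring, and its > 50000 nM is again only a limit, so a small shift toward weaker inhibition is expected, not clearly beyond the usual scatter. The estimate means an expected 1.7-fold higher number from compound 2 to compound 3 (0.24 log units; within the scatter). Compound 3 is estimated at 38000 nM, with an expected range of 15000 nM to 50000 nM.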

Compound 3, half-maximal inhibitory concentration: > 50000 nM
Compound 3 gave a limit, no number; the forecaster's own chance of this, stated with the estimate: 45%; middle value at least 1.3-fold (0.11 log units) away from the limit.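

Compound 3 gives > 50000 nM, which is a limit of the assay and not a number. Even so, the first direct measurement of this change is readable in this assay: putting 5-(nitrooxy)pentyl in place of hydrogen on an oxygen on an aromatic ring gives an at least 2.2-fold higher number from compound 2 to compound 3 (0.36 log units; beyond the scatter), so this position does not accept the chain without a weaker result. The true size of that step stays unknown, and the step between compound 1 and compound 3 cannot be read, because both compounds sit at the same limit: the limit of > 50000 nM in this assay, at which 2 of the 3 values shown sit.

The compounds shown leave open whether any group on this oxygen weakens the result or only 5-(nitrooxy)pentyl does. An ethyl group, or a chain ending in an amine or a carboxylic acid, on the same oxygen would help to separate these two cases.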